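The source may hold more compounds than are shown below. What is called first, only, known or untested is meant among the compounds shown, and "the series" means these compounds.

Measured compounds: compound 1 `O=C1CC(c2ccccc2O)Oc2ccccc21` with 71300 nM and compound 2 `CC(C)c1ccc(COc2ccccc2C2CC(=O)c3ccccc3O2)cc1` with 27100 nM in a functional assay on RAW264.7 cells (Mus musculus) for inhibition, read by Griess assay, with stated times of 1 h and 24 h; on this read-out lower numbers stand for stronger inhibition and higher numbers for weaker inhibition.

Of the two numbers measured, compound 2 stands at the lowest, and the gap to compound 1 lies beyond the scatter. Compound 3 `COCOc1ccccc1C1CC(=O)c2ccccc2O1` is not yet measured; it differs from compound 2 by methoxy in place of 4-isopropylphenyl on a saturated chain carbon bound to an oxygen on an aromatic ring. Compound 3 is expected to move back toward the number of compound 1, because compound 1 gives 71300 nM without the 4-isopropylphenyl group, so a step of a 2.0-fold higher number from compound 2 to compound 3 (0.31 log units; beyond the scatter) toward a higher number is estimated. Compound 3 is therefore expected to give 55000 nM, within 25000 nM to 120000 nM.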

Compound 3, half-maximal inhibitory concentration: 32600 nM
The estimate for compound 3 lay 1.7-fold (0.23 log units) above the measured number, and the stated range covers the measured number.
By their numbers in this assay, from the lowest: compounds 2 and 3 (each within the scatter of the next); then compound 1.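

In this assay, methoxy in place of 4-isopropylphenyl gives a 1.2-fold higher number from compound 2 to compound 3 (0.08 log units; within the scatter), so at this saturated chain carbon the aromatic ring of the leaving group is not required to keep the number of compound 2. Methoxymethyl in place of hydrogen on the oxygen on an aromatic ring already gives a modest step, a 2.2-fold lower number from compound 1 to compound 3 (0.34 log units; beyond the scatter). No measurement at hand explains either result. The compounds shown leave open whether an amine, a carboxylic acid or a longer chain at this place would move the number beyond the scatter.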